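From Piperidine to Tetrahydroisoquinoline on a Shared Core

A few compounds are considered here, and "the series" means these few. Any claim that something is new, unique, unknown or untested is made for them only; others in the source may bear on it.

Compound 3 `CNC(=O)c1cc(Oc2ccc(Nc3nccc(N4CCCCC4)n3)cc2)ccn1` gives 890 nM in a functional assay on A549 cells (Homo sapiens) for inhibition, read by MTT assay, with a stated time of 72 h (on this read-out higher numbers stand for weaker inhibition and lower numbers for stronger inhibition), and so holds the lowest of the three numbers measured, beyond the scatter from both of the others. Compound 1 `CNC(=O)c1cc(Oc2ccc(Nc3nccc(N4CCCC4)n3)cc2)ccn1` gives 3410 nM on the same read-out, and compound 2 `CCN(CC)c1ccc(C(=O)Nc2ccc(Oc3ncnc4ccsc34)cc2)cc1` gives 8030 nM as the highest of the three.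

Compound 4 `CNC(=O)c1cc(Oc2ccc(Nc3nccc(N4CCc5ccccc5C4)n3)cc2)ccn1` keeps the rest of compound 3 and carries 1,2,3,4-tetrahydroisoquinolin-2-yl in place of piperidin-1-yl on an aromatic carbon of the six-membered aromatic ring with 2 nitrogen. Among the compounds with values here, only one measured step bears on this change. Piperidin-1-yl in place of pyrrolidin-1-yl on that same carbon gave a 3.8-fold lower number from compound 1 to compound 3 (0.58 log units; beyond the scatter) and that step is modest. Within the data shown here, compound 2 has a different core and adds no step at this carbon. Among the measured compounds shown here, a single step makes no pattern, and no measured compound has an aromatic ring of carbon only in this group. A small further fall in this assay is therefore expected, smaller than the step already seen and possibly lost in the scatter. The expected change is a 1.4-fold lower number from compound 3 to compound 4 (0.14 log units; within the scatter) on this estimate. Compound 4 is expected at 650 nM within an estimated range of 180 nM to 2500 nM for this measurement.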

Compound 4, half-maximal inhibitory concentration: 3190 nM
For compound 4 the middle estimate is 4.9-fold (0.69 log units) below the measured one, outside the stated range (above it).
By their numbers in this assay, from the lowest: compound 3; then compounds 4 and 1 (each within the scatter of the next); then compound 2.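

With compound 4 the carbon on the shared core gains a second measured step from compound 3, and it runs the opposite way to the first: in this assay, the change to 1,2,3,4-tetrahydroisoquinolin-2-yl gives a 3.6-fold higher number from compound 3 to compound 4 (0.55 log units; beyond the scatter), a modest step, while the earlier change from pyrrolidin-1-yl to piperidin-1-yl gave a 3.8-fold lower number from compound 1 to compound 3 (0.58 log units; beyond the scatter). Among these three groups the number therefore does not move in one direction as the group on this carbon grows, and piperidin-1-yl stands apart from both of the others, whereas the remaining pair shows a 1.1-fold lower number from compound 1 to compound 4 (0.03 log units; within the scatter), so pyrrolidin-1-yl and 1,2,3,4-tetrahydroisoquinolin-2-yl cannot be told apart in this assay. No supporting information on why the added six-membered aromatic ring of carbon only raises the number is available here.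

The compounds shown leave open how other groups on this carbon, such as morpholin-4-yl, 4-methylpiperazin-1-yl or an open-chain diethylamino group, would stand against piperidin-1-yl. They also leave open whether a six-membered aromatic ring of carbon only would give the same step if it were joined to the pyrrolidin-1-yl ring or carried substituents.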